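From dimethylamino to diethylamino: compound 2 to compound 3

The compounds below may be only part of what the source reports. "The series", "measured", "known", "first", "only" and "open" are said of these compounds alone.

In a functional assay (aorta) with Rattus norvegicus as the target (a higher number here means that more compound is needed for the effect, a lower number that less compound is needed), compound 1 `CC/N=C(/NC#N)C1=CC(C)(C)Oc2ccc([N+](=O)[O-])cc21` gives 89.1 nM as a measured value. Compound 2 `CN(C)/C(=N\C#N)C1=CC(C)(C)Oc2ccc([N+](=O)[O-])cc21` has only < 31700 nM as its reading, and that is a limit and not a number. Going by the values given here, compound 3 `CCN(CC)/C(=N\C#N)C1=CC(C)(C)Oc2ccc([N+](=O)[O-])cc21` carries diethylamino in place of dimethylamino on a carbon with a double bond to nitrogen as its single change from compound 2. Among the compounds with values here, the only measured step bearing on this is a step that the limit leaves unreadable from compound 1 to compound 2 and it offers no size to carry over. The expected step that the limit leaves unreadable from compound 2 to compound 3 is therefore taken as small, with no change beyond the scatter expected in either direction. In this assay the estimate for compound 3 is 20000 nM with an expected range from 3000 nM to 60000 nM overall.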

Compound 3, half-maximal effective concentration: < 31700 nM
Compound 3 was reported as a limit; the forecaster's own chance of this, stated with the estimate: 50%; the middle value is on the limit's open side.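

No step can be read between compound 2 and compound 3, because both readings are limits and not numbers: the limit of < 31700 nM in this assay, at which 2 of the 3 values shown sit.

Going by these compounds, whether diethylamino and dimethylamino differ at all on this carbon stays open, and so does the true distance of either compound from compound 1.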